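Swapping Carboxy for Methylcarbamoyl: What Growth Inhibition May Show

This account rests on a few compounds, and the source may have more. Where it says the series, first, only, none or still open, it means among the compounds named here.

In a functional assay on HCT-116 cells (Homo sapiens) for inhibition, read by MTT assay, with a stated time of 72 h (on this read-out lower numbers stand for stronger inhibition of growth and higher numbers for weaker inhibition of growth), compound 1 `CCOC(=O)/C=C/c1ccncc1-c1ccc2c(ccn2C)c1` gives 210 nM, and compound 3 `Cn1ccc2cc(-c3cnccc3/C=C/C(=O)O)ccc21` gives 7260 nM, the higher of the two numbers available. Compound 2 `Cn1ccc2cc(-c3cnccc3/C=C/C(=O)N3CCOCC3)ccc21` adds no number, as its entry reads "not determined" (no result reported).

Compound 4 `CNC(=O)/C=C/c1ccncc1-c1ccc2c(ccn2C)c1` differs from compound 3 by methylamino in place of hydroxy on a carbonyl carbon, which turns carboxy into methylcarbamoyl. Within the data shown here, no measured compound carries this group, so any forecast rests on a single comparison. That comparison is a 35-fold higher number from compound 1 to compound 3 (1.54 log units; beyond the scatter), a large step beyond the scatter, in which hydrogen takes the place of ethyl on an oxygen of the same carboxy-derived group. Among the measured compounds shown here, compound 3 is thus the only measured compound with a free carboxy group, and one step is thin evidence. A sizeable move toward a lower number in this assay still seems likely, though probably not the whole distance back to the value of compound 1. The expected change is a 12-fold lower number from compound 3 to compound 4 (1.08 log units; beyond the scatter). For compound 4, the estimate is 600 nM, within an expected range of 120 nM to 3000 nM.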

Compound 4, concentration for 50% growth inhibition: 4450 nM
Compound 4: middle estimate off by 7.4-fold (0.87 log units), on the low side; the measured number lies above the stated range.
By their numbers in this assay, from the lowest: compound 1; then compounds 4 and 3 (each within the scatter of the next).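

In this assay, methylamino in place of hydroxy on this carbonyl carbon gives a 1.6-fold lower number from compound 3 to compound 4 (0.21 log units; within the scatter), so the carboxy and methylcarbamoyl groups cannot be told apart here. Methylamino in place of ethoxy on the same carbon gives a 21-fold higher number from compound 1 to compound 4 (1.33 log units; beyond the scatter), a large step much like the earlier 35-fold higher number from compound 1 to compound 3 (1.54 log units; beyond the scatter), so that earlier step is not unique to the free carboxy group. Of the three compounds with numbers, only compound 1, with ethoxy, stands apart, and no measurement here explains why.

On these data alone, whether methoxy, or a longer chain such as propoxy, on this carbonyl carbon would give a number close to that of compound 1 remains open. So does whether a larger amine, such as ethylamino or dimethylamino, would read differently from methylamino, and compound 2 offers no result to help.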